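The source may hold more compounds than are shown below. What is called first, only, known or untested is meant among the compounds shown, and "the series" means these compounds.

Working notes on the series. Within the data shown here, in an assay for inhibition of serine/threonine-protein kinase Sgk1 (Homo sapiens), with stated times of 30 min and 60 min, in the presence of a further agent that is not named here (on this read-out lower numbers stand for stronger inhibition and higher numbers for weaker inhibition), compound 1 `CN1CCC(NC(=O)c2cc(-c3ccc(NS(=O)(=O)c4cccc(Cl)c4Cl)cc3)nc3[nH]ncc23)C1` gives 21 nM and compound 2 `Cc1n[nH]c2nc(-c3ccc(NS(=O)(=O)c4cc(Cl)ccc4F)cc3)nc(OCCC(=O)N(C)C)c12` gives 438 nM; compound 2 thus stands highest of the two numbers so far, with compound 1 returning the lower number by a margin beyond the scatter. Among the measured compounds shown here, the two compounds differ in the core as well as the side chain, so no single step connects them. Compound 3 `Cc1n[nH]c2nc(-c3ccc(NS(=O)(=O)c4cc(Cl)ccc4F)cc3)nc(OCC3CN(C(C)C)C3)c12` carries 1-isopropylazetidin-3-yl in place of (dimethylcarbamoyl)methyl on a saturated chain carbon bound to an oxygen on an aromatic ring, the difference at this end being the exchange of the amide-bearing chain for a four-membered ring with a basic nitrogen, kept on the same oxygen linker. In this assay the expected step from compound 2 to compound 3 is a 2.9-fold lower number from compound 2 to compound 3 (0.47 log units; beyond the scatter), a modest move toward a lower number with wide uncertainty. The estimate for compound 3 in this assay is 150 nM, with a range of 40 nM to 600 nM.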

Compound 3, half-maximal inhibitory concentration: 1 nM
For compound 3 the middle estimate is 150-fold (2.18 log units) above the measured one; the whole stated range lies above it.
By their numbers in this assay, from the lowest: compound 3; then compound 1; then compound 2.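

On a saturated chain carbon bound to an oxygen on an aromatic ring, 1-isopropylazetidin-3-yl in place of (dimethylcarbamoyl)methyl gives a 440-fold lower number from compound 2 to compound 3 (2.64 log units; beyond the scatter) in this assay, so this position on the shared core can move the read-out strongly. Among these compounds, this is the first step that differs in one place, and it is large, yet it combines the loss of the amide-bearing chain with the entry of the four-membered ring. Nothing measured here accounts for the size of the step. The compounds shown leave open whether the ring itself is needed, or whether an open-chain dimethylamine on the same oxygen linker would do as well. They also leave open whether the isopropyl matters, which 1-methylazetidin-3-yl at this place would test.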